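Extending a methyl to an ethyl on compound 3

The source may hold more compounds than are shown below. What is called first, only, known or untested is meant among the compounds shown, and "the series" means these compounds.

Measured in an ADME assay on the whole organism (strain 129/SvEvBrd x C57BL/6) for metabolic stability, with Mus musculus as the target; on this read-out higher numbers stand for a longer-lived compound and lower numbers for a shorter-lived compound:
- Compound 1 `CC(=O)c1cccc([C@@H](O)[C@H](O)[C@H](O)CO)n1`: 2.1 h
- Compound 2 `CC(=O)c1ncc([C@@H](O)[C@H](O)[C@H](O)CO)s1`: 0.9 h
- Compound 3 `CC(=O)c1nc([C@@H](O)[C@H](O)[C@H](O)CO)c(C)[nH]1`: 6.2 h

Of these three, compound 3 has the longest half-life, and its gaps to compound 1 and to compound 2 both lie beyond the scatter. The three compounds differ in their cores, however, and no two of them differ in just one place. Their values therefore show where each compound stands but do not reveal what a small change on any one core would do.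

The next compound, compound 4 `CCc1[nH]c(C(C)=O)nc1[C@@H](O)[C@H](O)[C@H](O)CO`, differs from compound 3 by methyl in place of hydrogen on a saturated chain carbon bound to an aromatic carbon. This is methyl in place of hydrogen on a saturated chain carbon bound to an aromatic carbon, or, read one bond further out, methyl to ethyl. Among the measured compounds shown here, no measured pair isolates this change, so the expectation rests mainly on compound 3 at 6.2 h and on the small size of the change. The estimate is a slight decrease, a 1.2-fold lower number from compound 3 to compound 4 (0.08 log units; within the scatter), which is expected to stay within the scatter. In this assay, compound 4 is expected to give 5.2 h, with an estimated range from 2.5 h to 11 h.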

Compound 4, half-life: 2.8 h
Beside the measured number, compound 4's estimate is 1.9-fold (0.27 log units) above it; the range from low to high includes it.
By their numbers in this assay, from the lowest: compound 2; then compounds 1 and 4 (each within the scatter of the next); then compound 3.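

In this assay, among the compounds shown here, this pair gives the first reading of a single change on one core: extending the methyl on a saturated chain carbon bound to an aromatic carbon to an ethyl gives a 2.2-fold lower number from compound 3 to compound 4 (0.35 log units; beyond the scatter). The earlier compounds shown here, which differ in their cores, could show only where each one stood, whereas this step shows that the half-life responds to this position and that adding just 1 heavy atom there is enough to move it beyond the scatter, though only modestly. Nothing available explains why the half-life falls with this change.

From the compounds shown here alone, a single step sets no trend, so it remains open whether a longer chain such as propyl, a branched group such as isopropyl, or a hydroxymethyl group at this place would shorten the half-life further, leave it about where it stands, or restore it. Going by these compounds, it also remains open whether hydrogen in place of the methyl of compound 3 would change the half-life, and in which direction.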